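The source may hold more compounds than are shown below. What is called first, only, known or untested is meant among the compounds shown, and "the series" means these compounds.

Compound 1 `O=C(/C=C/C1=Cc2ccccc2OC1)c1ccc(Cl)cc1` and compound 2 `O=C(/C=C/C1=Cc2ccccc2OC1)c1ccc(Br)cc1` share the core and differ only at the para substituent of the aryl ketone. In a functional assay on the whole organism for inhibition, with Mus musculus as the target, with a stated time of 1 h, at a dose of 30 mg/kg by the intraperitoneal route (a higher number here means more inhibition at the dose given (going by the name of the read-out), a lower number less inhibition), compound 1 gives 56.1%, and in this assay compound 2 gives 66%. Among the compounds with values here, the only step measured, a number 9.9 percentage points higher from compound 1 to compound 2 (within the scatter), is within the scatter, so compound 2 stands with the higher of the two numbers but is not separated from compound 1. Compound 3 `O=C(/C=C/C1=Cc2ccccc2OC1)c1ccc(C(F)(F)F)cc1` is not yet measured; it carries trifluoromethyl in place of bromo on an aromatic carbon. Within the data shown here, no measured step covers this change; the one step at this position was within the scatter, so a step of no more than the scatter is expected in this assay. Compound 3 is therefore estimated at 60%, in the range 40% to 80%. The expected step from compound 2 is a number 6 percentage points lower from compound 2 to compound 3 (within the scatter).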

Compound 3, a percentage reported as inhibition, in the whole organism at one dose (the size of the read-out at that dose, not a potency): 75.5%
Estimate against measurement, compound 3: 15.5 percentage points below; the range from low to high includes it.
By their numbers in this assay, from the lowest: compounds 1, 2 and 3 (each within the scatter of the next, the first and the last beyond it).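

At this position, trifluoromethyl in place of bromo gives a number 9.5 percentage points higher from compound 2 to compound 3 (within the scatter) in this assay and does not separate the two compounds. Trifluoromethyl in place of chloro gives a number 19.4 percentage points higher from compound 1 to compound 3 (beyond the scatter) and is the first step here beyond the scatter, so the position responds to the group it carries, though modestly. Nothing measured bears on the reason for this step.

On these data alone, how an amine or a carboxylic acid would behave at this position remains open. So does whether a longer chain would hold the level seen with trifluoromethyl.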